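The compounds below may be only part of what the source reports. "The series", "measured", "known", "first", "only" and "open" are said of these compounds alone.

Measured in a functional assay on ileum (strain Hartley) for agonist activity at 5-hydroxytryptamine receptor 3A (Cavia porcellus); a higher number here means a more potent compound, by a factor of ten per unit of this negative logarithm, a lower number a less potent compound:
compound 1 `COc1cc(Cl)cc2nc(N3CCN(C)CC3)oc12` gives 6.16.
Compound 2 `COc1cc(C)cc2nc(N3CCN(C)CC3)oc12` gives 6.13.
Compound 3 `COc1cccc2nc(N3CCN(C)CC3)oc12` gives only a limit of the assay, < 4.

Compound 1 stands highest of the two numbers; the nearest is compound 2, with a number 0.03 log units lower from compound 1 to compound 2 (within the scatter). Removing the chloro gives a number at least 2.16 log units lower from compound 1 to compound 3 (beyond the scatter); removing the methyl gives a number at least 2.13 log units lower from compound 2 to compound 3 (beyond the scatter); both run into (the limit of < 4 in this assay, at which 1 of the 3 values shown sits).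

Compound 4 `CCc1cc(Cl)cc2nc(N3CCN(C)CC3)oc12` differs from compound 1 by ethyl in place of methoxy on an aromatic carbon. Among the compounds with values here, none of the measured steps touches this change: all three vary the chloro/methyl site, and the methoxy is kept throughout. Within the data shown here, the series therefore offers no direct precedent, and the expectation rests on the size of the shared core alone. A moderate loss is expected, a number 0.66 log units lower from compound 1 to compound 4 (beyond the scatter), so that compound 4 is estimated at 5.5, in the range 4.3 to 6.5.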

Compound 4, negative logarithm of the half-maximal effective concentration: 6.82
Compound 4: middle estimate off by 1.32 log units, on the low side; the whole stated range lies below it.
By their numbers in this assay, from the lowest: compounds 2 and 1 (each within the scatter of the next); then compound 4. At a limit, below all of these: compound 3.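

In this assay, the methoxy position, held constant in compounds 1 to 3, proves open to change: ethyl in place of methoxy gives a number 0.66 log units higher from compound 1 to compound 4 (beyond the scatter). With the chloro kept, the oxygen of the methoxy is therefore not required for agonist potency on the shared core. Nothing measured in the series bears on why the number rises.

Going by these compounds, whether the same gain holds with methyl in place of the chloro remains open. So does the outcome at this position for a longer chain such as propyl, for a hydroxyl or for an amine.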